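The source may report more compounds than this note shows. Statements on the series, on what has been measured and on what is new or still open speak of the compounds shown alone.

Going by the values given here, in an ADME assay on HeLa cells (Homo sapiens) for cytotoxicity, read by MTT assay, with a stated time of 72 h (a higher number here means that more compound is tolerated, a lower number that less compound is tolerated), compound 1 `C(=N/c1sc2c(c1-c1nc3ccccc3s1)CCCC2)\c1ccccc1` gives 333 ug/mL and compound 2 `Clc1ccccc1/C=N/c1sc2c(c1-c1nc3ccccc3s1)CCCC2` gives 407 ug/mL, so compound 2 stands level with compound 1 on the only two numbers available. Compound 3 `FC(F)(F)c1ccc(/C=N/c2sc3c(c2-c2nc4ccccc4s2)CCCC3)cc1` differs from compound 2 by a single change, (4-(trifluoromethyl)phenyl in place of 2-chlorophenyl on a carbon with a double bond to nitrogen). Among the compounds with values here, the one measured step that bears on it is a 1.2-fold higher number from compound 1 to compound 2 (0.09 log units; within the scatter), with chloro in place of hydrogen on an aromatic carbon. Neither measured compound carries trifluoromethyl. On that one small step, no change beyond the scatter is expected in this assay. The expected step is a 1.1-fold lower number from compound 2 to compound 3 (0.03 log units; within the scatter). For compound 3 the estimated value is 380 ug/mL, with an expected range of 190 ug/mL to 760 ug/mL.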

Compound 3, half-maximal cytotoxic concentration: 369 ug/mL
Compound 3: the middle estimate sits 1.0-fold (0.01 log units) above what was measured, within the range that was stated.
By their numbers in this assay, from the lowest: compounds 1, 3 and 2 (each within the scatter of the next).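

In this assay, 4-(trifluoromethyl)phenyl in place of 2-chlorophenyl on a carbon with a double bond to nitrogen gives a 1.1-fold lower number from compound 2 to compound 3 (0.04 log units; within the scatter), and a trifluoromethyl group taking the place of hydrogen on an aromatic carbon gives a 1.1-fold higher number from compound 1 to compound 3 (0.04 log units; within the scatter). Trifluoromethyl thus joins chloro as a second substituent on this aromatic ring that leaves the number within the scatter, and compounds 1, 2 and 3 cannot be told apart here. Nothing available bears on the reason for this. As far as these compounds go, whether an amine or a carboxylic acid on this ring would shift the number beyond the scatter remains open.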